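Two measured compounds and one change still to test

This account rests on a few compounds, and the source may have more. Where it says the series, first, only, none or still open, it means among the compounds named here.

Measured so far:
compound 1 `CC/N=C(/NC#N)NCCCn1nc(-c2ccccc2)ccc1=O` gives 88.5 mg/kg
compound 2 `O=c1ccc(-c2ccccc2)nn1CCCCNC(=S)Nc1ccccc1` gives > 100 mg/kg

Among the compounds with values here, in a functional assay on the whole organism with Rattus norvegicus as the target (on this read-out higher numbers stand for an effect only at larger amounts of compound and lower numbers for an effect already at smaller amounts), compound 1 gives 88.5 mg/kg and is the only compound with a number rather than a limit. For compound 2 the value > 100 mg/kg is a limit of this assay, not a number. Within the data shown here, compound 1 therefore stands at the one real number here, with the other entry sitting at the limit of > 100 mg/kg in this assay, at which 1 of the 2 values shown sits.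

The compound not yet measured is compound 3 `C/N=C(\S)NCCCn1nc(-c2ccccc2)ccc1=O`. It differs from compound 1 in one place: a group of 4 heavy atoms (2 carbon, 1 nitrogen, 1 sulfur; no ring) in place of a group of 7 heavy atoms (4 carbon, 3 nitrogen; no ring), on an amine nitrogen. Among the measured compounds shown here, no pair of measured compounds differs in just one place, so no measured step can serve as a guide for this change, and the two measured values show only that compound 1 has a number and compound 2 a limit.

For this assay the step of a 1.0-fold higher number from compound 1 to compound 3 (0.01 log units; within the scatter) is expected to stay within the usual scatter, with no clear direction. Compound 3 is thus estimated at 90 mg/kg, with a range from 40 mg/kg to 200 mg/kg, and a real chance that only a limit is reported.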

Compound 3, dose for half-maximal effect: 58 mg/kg
Beside the measured number, compound 3's estimate is 1.6-fold (0.19 log units) above it; low and high end bracket the measured number.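

Swapping the group of 7 heavy atoms (4 carbon, 3 nitrogen; no ring) for the smaller group of 4 heavy atoms (2 carbon, 1 nitrogen, 1 sulfur; no ring) on the amine nitrogen gives, in this assay, a 1.5-fold lower number from compound 1 to compound 3 (0.18 log units; within the scatter). Within the data shown here, this is the first measured step at this position, and it shows that the two groups cannot be told apart on this read-out, even though they differ in size and in their atoms, so at this position the whole-animal effect survives the exchange. Among these compounds, nothing measured so far bears on why the two groups read alike.

The compounds shown leave open whether the same position accepts a group of a different kind, such as a carboxylic acid or a morpholine ring, on the same amine nitrogen. Going by these compounds, it also remains open whether the sulfur matters at all, which a version of the group in compound 3 carrying oxygen in place of sulfur could help to settle.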